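Chloro in Place of Methyl: An Expected Edema Result

The compounds below may be only part of what the source reports. "The series", "measured", "known", "first", "only" and "open" are said of these compounds alone.

Compound 1 `CC(=O)c1c(NNc2ccccc2)cc(C)oc1=O` and compound 2 `CC(=O)c1c(NNc2ccc(C)cc2)cc(C)oc1=O` share one core and differ only by a methyl group on an aromatic carbon. In a functional assay on the whole organism for inhibition, with Rattus norvegicus as the target, read by paw edema, with a stated time of 4 h, at a dose of 50 mg/kg (a lower number here means less inhibition, a higher number more inhibition at the dose given (going by the name of the read-out)), compound 1 gives 52%, and compound 2 gives 50%. The step of a number 2 percentage points lower from compound 1 to compound 2 (within the scatter) lies within the scatter, so the two cannot be told apart. Compound 2 shows the smaller of the two recorded numbers, but only by a difference that the scatter covers. Compound 3 `CC(=O)c1c(NNc2ccc(Cl)cc2)cc(C)oc1=O` has not yet been measured; it differs from compound 2 by chloro in place of methyl on an aromatic carbon. Going by the values given here, only one measured step is available, and it concerns a different group, but it shows that a change on that aromatic carbon gave no shift beyond the scatter. No shift beyond the scatter is therefore expected for compound 3 in this assay, an expected step of no change at the digits printed from compound 2 to compound 3 (within the scatter). Compound 3 is estimated at 50%, within a range from 38% to 62%.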

Compound 3, a percentage reported as inhibition, in the whole organism at one dose (the size of the read-out at that dose, not a potency): 28.4%
Compound 3: middle estimate off by 21.6 percentage points, on the high side; the measured number lies below the stated range.
By their numbers in this assay, from the lowest: compound 3; then compounds 2 and 1 (each within the scatter of the next).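

In this assay, this position on the aromatic carbon para to a large group is not indifferent to what sits there, as the earlier pair with methyl and hydrogen could not show. Chloro in place of methyl gives a number 21.6 percentage points lower from compound 2 to compound 3 (beyond the scatter), and chloro in place of hydrogen gives a number 23.6 percentage points lower from compound 1 to compound 3 (beyond the scatter), so chloro stands apart from both of the other groups, while those two remain within the scatter of each other. Nothing available explains why chloro behaves differently here.

The compounds shown leave open whether this lower inhibition belongs to chloro alone or would also appear with another group at this place, such as fluoro, methoxy or an amine. They also leave open whether chloro on a different aromatic carbon would give a similar result.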